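Thiophen-3-yl in place of 4-(dimethylamino)phenyl

The source may hold more compounds than are shown below. What is called first, only, known or untested is meant among the compounds shown, and "the series" means these compounds.

In a functional assay on HepG2 cells (Homo sapiens) for antiproliferative activity, read by MTT assay, with a stated time of 24 h (on this read-out lower numbers stand for stronger inhibition and higher numbers for weaker inhibition), compound 1 `COc1ccc(C(=O)/C=C/c2ccc(N(C)C)cc2)c2c1C=CC(C)(C)O2` gives 730 nM and holds the lowest of the two numbers in the series. Compound 3 `COc1ccc(C(=O)/C=C/c2ccc(N3CCCC3)cc2)c2c1C=CC(C)(C)O2` gives 4740 nM in this assay on the same read-out. Compound 2 `COc1ccc(C(=O)/C=C/c2ccc(-c3ccccc3)cc2)c2c1C=CC(C)(C)O2` reads > 10000 nM and this is a limit of the assay, not a number.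

Compound 4 `COc1ccc(C(=O)/C=C/c2ccsc2)c2c1C=CC(C)(C)O2` carries thiophen-3-yl in place of 4-(dimethylamino)phenyl on a double-bonded chain carbon bound to a double-bonded chain carbon. Going by the values given here, two measured steps bear on this change, an at least 13-fold higher number from compound 1 to compound 2 (1.13 log units; beyond the scatter) and a 6.5-fold higher number from compound 1 to compound 3 (0.81 log units; beyond the scatter), and both leave compound 1 for a higher number. Neither removes the whole group, so they are only a partial guide. A modest rise is therefore expected in this assay, with a 6.8-fold higher number from compound 1 to compound 4 (0.84 log units; beyond the scatter) as the estimated step. For compound 4 the estimate is 5000 nM, with an expected range from 1400 nM to 14000 nM overall.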

Compound 4, half-maximal inhibitory concentration: > 10000 nM
Compound 4 was reported as a limit; the forecaster's own chance of this, stated with the estimate: 30%; middle value at least 2.0-fold (0.30 log units) away from the limit.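

Going by these compounds alone, replacing the whole 4-(dimethylamino)phenyl with thiophen-3-yl gives an at least 13-fold higher number from compound 1 to compound 4 (1.13 log units; beyond the scatter) in this assay, whereas the earlier steps kept the six-membered aromatic ring and changed only its substituent. Compound 4 reads > 10000 nM, which is a limit of the assay and not a number. Compounds at this limit cannot be ordered against each other: the limit of > 10000 nM in this assay, at which 2 of the 4 values shown sit.

The compounds shown do not separate the loss of the dimethylamino group from the change of ring. A thiophen-3-yl bearing a dimethylamino group, or a 4-(diethylamino)phenyl, would test how far each contributes.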